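Swapping methoxy for nitro: an untested analogue of compound 1

The source may hold more compounds than are shown below. What is called first, only, known or untested is meant among the compounds shown, and "the series" means these compounds.

compound 1 `COc1ccc(C(=O)Nc2nc3cc(C)cc(C)c3s2)cc1`: 1.03 ug/mL
compound 2 `Cc1ccc2nc(NC(=O)Nc3cccc([N+](=O)[O-])c3)sc2c1`: > 10 ug/mL
compound 3 `COc1ccc(NC(=O)Nc2nc3ccc(F)cc3s2)cc1`: > 10 ug/mL

Three compounds were tested in a functional assay on MDA-MB-231 cells (Homo sapiens) for antiproliferative activity, read by sulforhodamine B assay; a higher number here means a weaker inhibitor of growth, a lower number a stronger inhibitor of growth. Compound 1 gives 1.03 ug/mL, the only numerical result among them. For compound 2 the assay reports only a limit, > 10 ug/mL. For compound 3 it likewise reports only a limit, > 10 ug/mL. Compound 1 thus stands alone as a number, the two others sitting at the limit of > 10 ug/mL in this assay, at which 2 of the 3 values shown sit. Compound 4 `Cc1cc(C)c2sc(NC(=O)c3ccc([N+](=O)[O-])cc3)nc2c1` awaits measurement; it differs from compound 1 by nitro in place of methoxy on an aromatic carbon. Among the measured compounds shown here, no measured pair isolates this change, so the data give no step size for it. The author expects a small loss of potency, estimating the step from compound 1 to compound 4 at a 1.9-fold higher number from compound 1 to compound 4 (0.29 log units; within the scatter). Compound 4 is estimated at 2 ug/mL, ranging from 0.5 ug/mL to 8 ug/mL.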

Compound 4, concentration for 50% growth inhibition: 0.29 ug/mL
Estimate against measurement, compound 4: 6.9-fold (0.84 log units) above; the whole stated range lies above it.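

In this assay, nitro in place of methoxy on an aromatic carbon, para to a large group, gives a 3.6-fold lower number from compound 1 to compound 4 (0.55 log units; beyond the scatter), so this position accepts the exchange and growth inhibition becomes stronger. Among the compounds shown here, this is the first step that can be read here, as the earlier compounds included no pair differing in one place. Nothing in the data shown accounts for the gain.

From the compounds shown here alone, whether an amine or a nitrile at this position would match nitro remains open. So does whether nitro would give a similar step on a different core.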